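Replacing the 1,3-benzothiazol-2-yl group on a shared core

This account rests on a few compounds, and the source may have more. Where it says the series, first, only, none or still open, it means among the compounds named here.

In a functional assay on Bel-7402 cells (Homo sapiens) for cytotoxicity, read by MTT assay, with a stated time of 48 h (on this read-out higher numbers stand for weaker inhibition and lower numbers for stronger inhibition), compound 1 `CCn1cc(-c2nc3ccccc3s2)c(=O)c2cc(F)c(N3CCNCC3)nc21` gives 2400 nM. Compound 3 `CCn1cc(-c2nc3ccc([N+](=O)[O-])cc3s2)c(=O)c2cc(F)c(N3CCNC(C)C3)c(F)c21` gives 4100 nM, within the usual scatter of compound 1. Among the measured compounds shown here, compound 2 `CCn1cc(-c2nc3ccc([N+](=O)[O-])cc3s2)c(=O)c2cc(F)c(N3CCNCC3)nc21` gives 24600 nM, the only value far from that of compound 1.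

Compound 4 `CCn1cc(-c2nc3ccc(N)cc3[nH]2)c(=O)c2cc(F)c(N3CCNCC3)nc21` has not yet been measured. It keeps the core of compound 1, and the change is this: a group of 10 heavy atoms (7 carbon, 3 nitrogen; one five-membered aromatic ring with 2 hetero atoms, one six-membered aromatic ring of carbon only) in place of a group of 9 heavy atoms (7 carbon, 1 nitrogen, 1 sulfur; one five-membered aromatic ring with 2 hetero atoms, one six-membered aromatic ring of carbon only), on an aromatic carbon.

For the measured compounds named here, the one measured step in a single place is a 10-fold higher number from compound 1 to compound 2 (1.01 log units; beyond the scatter), with nitro in place of hydrogen on an aromatic carbon of the 1,3-benzothiazol-2-yl group. Compound 3 also carries nitro but differs elsewhere too, so it offers no clean comparison. Compound 4 carries no nitro, which makes that large step only a loose guide. A smaller move toward a higher number, meaning weaker inhibition, is expected, and the estimated step is a 2.5-fold higher number from compound 1 to compound 4 (0.40 log units; beyond the scatter). The estimate for compound 4 is 6000 nM, with an expected range from 1500 nM to 24000 nM.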

Compound 4, half-maximal inhibitory concentration: 93300 nM
For compound 4 the middle estimate is 16-fold (1.19 log units) below the measured one; measured number outside the range, above it.
By their numbers in this assay, from the lowest: compounds 1 and 3 (each within the scatter of the next); then compound 2; then compound 4.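

In this assay, the exchange of the whole 1,3-benzothiazol-2-yl group gives a 39-fold higher number from compound 1 to compound 4 (1.59 log units; beyond the scatter) and is the largest step from compound 1 shown so far. The earlier step altered only a substituent on that group, whereas this one shows that replacing the group itself, at this position on the shared core, can cost far more activity even without a nitro group. No measurement available here accounts for the loss.

Compound 4 differs from compound 1 both in the ring atoms, with sulfur gone and nitrogen in its place, and in the added amine, so this one step cannot show how much each change contributes. As far as these compounds go, it also remains open how a methoxy group or a chlorine atom in place of hydrogen on the 1,3-benzothiazol-2-yl group would read in this assay.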